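Azido in place of dimethylamino on the nucleoside core

The compounds below may be only part of what the source reports. "The series", "measured", "known", "first", "only" and "open" are said of these compounds alone.

Measured compounds in a functional assay on the whole organism (Pleural cavity) with Rattus norvegicus as the target; on this read-out lower numbers stand for an effect already at smaller amounts and higher numbers for an effect only at larger amounts of compound:
compound 1 `OC[C@H]1OC(n2cnc3c(SCc4ccccc4)nccc32)[C@H](O)[C@@H]1O`: 9 mg/kg
compound 2 `OC[C@H]1OC(n2cnc3c(Nc4ccccc4)nccc32)[C@H](O)[C@@H]1O`: a limit of the assay, > 9 mg/kg
compound 3 `CN(C)c1nccc2c1ncn2C1O[C@H](CO)[C@@H](O)[C@H]1O`: a limit of the assay, > 9 mg/kg

Compound 3 has no number of its own; it stands at the limit of > 9 mg/kg in this assay, at which 2 of the 3 values shown sit. Compound 4 `[N-]=[N+]=Nc1nccc2c1ncn2C1O[C@H](CO)[C@@H](O)[C@H]1O` differs from compound 3 by azido in place of dimethylamino on an aromatic carbon. Among the compounds with values here, the measured steps that reach compound 3 are a number no lower from compound 1 to compound 3 (the limit leaves the size open) and a step that the two limits leave unreadable from compound 2 to compound 3, and both leave their size open; no measured step exchanges dimethylamino for azido. Compound 4 is therefore expected to stay near its parent, with an estimated step that the limit leaves unreadable from compound 3 to compound 4. Compound 4 is estimated at 15 mg/kg, between 5 mg/kg and 45 mg/kg, and a further limit rather than a number is quite possible.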

Compound 4, dose for half-maximal effect: > 9 mg/kg
Compound 4: no number, only a limit; the forecaster's own chance of this, stated with the estimate: 55%; the middle value lies beyond the limit too.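

In this assay compound 4 also gives only a limit, > 9 mg/kg. Azido, on the aromatic carbon next to the ring nitrogen, thus joins anilino and dimethylamino without a number, benzylsulfanyl remains the only group there with one, and the sole step with a direction is a number no lower from compound 1 to compound 4 (the limit leaves the size open). The steps among the three limited compounds cannot be read, and the limit now holds most of the series: the limit of > 9 mg/kg in this assay, at which 3 of the 4 values shown sit.

Going by these compounds, how far beyond the limit these three compounds lie stays open. So does whether benzyloxy or a plain amine at this carbon would give a number.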